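Dichlorobenzyl swap carried from one core to a second

The source may report more compounds than this note shows. Statements on the series, on what has been measured and on what is new or still open speak of the compounds shown alone.

Compound 1 `Cc1ccc(NC(=S)NC(=O)c2ccc(OCc3ccccc3Cl)cc2)cc1-c1nc2ccccc2[nH]1` and compound 2 `Cc1ccc(NC(=S)NC(=O)c2ccc(OCc3ccc(Cl)c(Cl)c3)cc2)cc1-c1nc2ccccc2[nH]1` share one core; compound 3 `Cc1ccc(NC(=O)NC(=O)c2ccc(OCc3ccccc3Cl)cc2)cc1-c1nc2ccccc2[nH]1` and compound 4 `Cc1ccc(NC(=O)NC(=O)c2ccc(OCc3ccc(Cl)c(Cl)c3)cc2)cc1-c1nc2ccccc2[nH]1` share a second. The difference between the two cores is not broken down here. In a functional assay on HT-29 cells (Homo sapiens) for inhibition, read by MTT assay, with a stated time of 48 h (a lower number here means a stronger inhibitor, a higher number a weaker inhibitor), compound 1 gives 23700 nM, while compound 2 gives 6270 nM. The structural change between the two, (3,4-dichlorophenyl in place of 2-chlorophenyl on a saturated chain carbon bound to an oxygen on an aromatic ring), made a 3.8-fold lower number from compound 1 to compound 2 (0.58 log units; beyond the scatter). On the second core, compound 3 gives 9010 nM in this assay; this lies within the usual scatter of compound 2 and is a higher number than compound 1 by a margin beyond that scatter. Compound 4 has not yet been measured. It differs from compound 3 by 3,4-dichlorophenyl in place of 2-chlorophenyl on a saturated chain carbon bound to an oxygen on an aromatic ring, which is the same change that turned compound 1 into compound 2; the place of the change reads identically in both cases, so it counts as the same change rather than merely the same kind. Within the data shown here, only one measured example of this change exists, and only on the first core, so how far it carries across rests on a single step. The step from compound 3 to compound 4 in this assay is expected to be about a 3.5-fold lower number from compound 3 to compound 4 (0.54 log units; beyond the scatter), resting on a 3.8-fold lower number from compound 1 to compound 2 (0.58 log units; beyond the scatter). Compound 4 is accordingly estimated at 2600 nM, with a range from 1100 nM to 7000 nM to allow for the step being smaller or larger on the second core.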

Compound 4, half-maximal inhibitory concentration: 1030 nM
Compound 4: middle estimate off by 2.5-fold (0.40 log units), on the high side, outside the stated range (below it).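

On the second core, 3,4-dichlorophenyl in place of 2-chlorophenyl on a saturated chain carbon bound to an oxygen on an aromatic ring gives an 8.7-fold lower number from compound 3 to compound 4 (0.94 log units; beyond the scatter) in this assay and so repeats the direction seen on the first core. Among these compounds, with only one pair on each core, this supports carrying the change between these two cores alone; it says nothing about any other core and gives no reason for the direction of the step. The larger number for the second core should not be read as a stronger effect of the change on that core, as the two steps cannot be told apart in size: the same change on two cores in this assay, a 3.8-fold lower number (0.58 log units; beyond the scatter) from compound 1 to compound 2 and an 8.7-fold lower number (0.94 log units; beyond the scatter) from compound 3 to compound 4, 2.3-fold (0.36 log units) apart, within the scatter of two such steps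

Each step swaps one whole chlorine pattern for another, so the compounds shown do not separate the loss of the 2-chloro substituent from the gain of the 3,4-dichloro pair. As far as these compounds go, it also remains open whether a methoxy or trifluoromethyl group on this phenyl ring, or a longer chain in place of the single saturated carbon bound to the oxygen, would keep the same direction on both cores.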